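Adding a Benzoyl Group to Compound 3

This account rests on a few compounds, and the source may have more. Where it says the series, first, only, none or still open, it means among the compounds named here.

Among the compounds with values here, in a functional assay on HEL cells (Homo sapiens) (a higher number here means that more compound is tolerated, a lower number that less compound is tolerated), compound 3 `Cc1cn([C@@H]2O[C@H](CO[Si](C)(C)C(C)(C)C)[C@@]3(OS(=O)(=O)C=C3NC(N)=O)[C@H]2O[Si](C)(C)C(C)(C)C)c(=O)n(C)c1=O` gives 11000 nM, the lower of the two true numbers so far, and compound 1 `Cc1cn([C@@H]2O[C@H](CO[Si](C)(C)C(C)(C)C)[C@@]3(OS(=O)(=O)C=C3NCC(=O)C(=O)N3CCC3)[C@H]2O[Si](C)(C)C(C)(C)C)c(=O)n(C)c1=O` gives 84400 nM. Compound 2 `Cc1cn([C@@H]2O[C@@H]3COC(=O)[C@]3(OS(C)(=O)=O)[C@H]2O)c(=O)[nH]c1=O` is recorded only as a limit, >= 36000 nM. Compound 4 `Cc1cn([C@@H]2O[C@H](CO[Si](C)(C)C(C)(C)C)[C@@]3(OS(=O)(=O)C=C3NC(=O)NC(=O)c3ccccc3)[C@H]2O[Si](C)(C)C(C)(C)C)c(=O)n(C)c1=O` carries benzoyl in place of hydrogen on an amide-type nitrogen. Within the data shown here, one measured step bears on this change: a 7.7-fold lower number from compound 1 to compound 3 (0.88 log units; beyond the scatter), with carbamoyl replacing (((azetidin-1-yl)carbonyl)carbonyl)methyl on an amine nitrogen. That modest step shows that this substituent matters, and compound 1, with the larger group, holds the higher number. A smaller rise in this assay is therefore expected, and the estimated change is a 1.8-fold higher number from compound 3 to compound 4 (0.26 log units; within the scatter). For compound 4 the estimated value is 20000 nM, within an expected range of 6000 nM to 70000 nM.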

Compound 4, half-maximal cytotoxic concentration: >= 200000 nM
Compound 4 was reported as a limit; the forecaster's own chance of this, stated with the estimate: 15%; middle value at least 10-fold (1.00 log units) away from the limit.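

In this assay, benzoyl on the amide-type nitrogen gives an at least 18-fold higher number from compound 3 to compound 4 (1.25 log units; beyond the scatter), so one added group at this place shifts the tolerated amount by a large step. The benzoylcarbamoyl group of compound 4 also overtakes the substituent of compound 1, with an at least 2.3-fold higher number from compound 1 to compound 4 (0.37 log units; beyond the scatter). Compound 4 is recorded as a limit, not a number: the limit of >= 200000 nM in this assay, at which 1 of the 4 values shown sits.

On these data alone, how far the true value of compound 4 lies past that limit stays open, as does whether the aromatic ring or the added carbonyl accounts for the step. An acetyl or cyclohexanecarbonyl group on the same nitrogen would separate the two.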